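Ethyl to ethoxy on the aryl group of compound 3

The source may report more compounds than this note shows. Statements on the series, on what has been measured and on what is new or still open speak of the compounds shown alone.

Compound 3 `CCc1ccccc1-n1nncc1CN1C(=O)C2(C(C#N)=C(N)Oc3c(N)cc4nc5ccccc5nc4c32)c2ccccc21` gives 22900 nM in an ADME assay on L02 cells (Homo sapiens) for antiproliferative activity, read by MTT assay, with a stated time of 48 h (a higher number here means a weaker inhibitor, a lower number a stronger inhibitor), the lowest of the two numbers recorded there. Compound 1 `N#CC1=C(N)Oc2c(c3nc4ccccc4nc3c3ccccc23)C12C(=O)N(Cc1cnnn1-c1cccc(Cl)c1)c1ccccc12` gives 35200 nM in this assay, and its gap to compound 3 lies within the scatter, so no order between the two is claimed. For compound 2 `N#CC1=C(N)Oc2c(c3nc4ccccc4nc3c3ccccc23)C12C(=O)N(Cc1cnnn1-c1ccc(N)cc1)c1ccccc12` this assay reports only a limit, > 50000 nM. Within the data shown here, the one measured step, an at least 1.4-fold higher number from compound 1 to compound 2 (0.15 log units; that floor lies within the scatter), concerns a different change on the aromatic nitrogen, and its upper end is set by the limit of > 50000 nM in this assay, at which 1 of the 3 values shown sits, so its full size is not known.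

Compound 4 `CCOc1ccccc1-n1nncc1CN1C(=O)C2(C(C#N)=C(N)Oc3c(N)cc4nc5ccccc5nc4c32)c2ccccc21` differs from compound 3 in one place: ethoxy in place of ethyl on an aromatic carbon. Among the measured compounds shown here, no measured pair in the set alters that position on the six-membered aromatic ring of carbon only, so nothing bears directly on this step, and the only step available concerns another group and rests on a limit. The expectation is therefore a step of no clear direction beyond the scatter, a 1.1-fold higher number from compound 3 to compound 4 (0.04 log units; within the scatter). Compound 4 is expected to give 25000 nM in this assay, estimated between 10000 nM and 50000 nM, with some chance that this assay reports only a limit for it.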

Compound 4, half-maximal inhibitory concentration: > 50000 nM
Compound 4: only a limit was reported; the forecaster's own chance of this, stated with the estimate: 25%; middle value at least 2.0-fold (0.30 log units) from the limit.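

Ethoxy in place of ethyl on an aromatic carbon, ortho to a large group, gives an at least 2.1-fold higher number from compound 3 to compound 4 (0.33 log units; beyond the scatter) in this assay, the only step shown that is printed as beyond the scatter. Among these compounds, until now the one available step, an at least 1.4-fold higher number from compound 1 to compound 2 (0.15 log units; that floor lies within the scatter), concerned a different change and had a floor within the scatter, so it said nothing about this position; the position now proves able to move the number in this assay, and in the direction of a weaker inhibitor. Compound 4 has only a limit in this assay, not a number, so the step is a floor and its full size stays unknown: the limit of > 50000 nM in this assay, at which 2 of the 4 values shown sit.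

With only 2-ethylphenyl and 2-ethoxyphenyl at this place, the compounds shown do not separate the added oxygen from the added heavy atom, and a methoxy or a propyl group on the same carbon would tell the two apart. They also leave open whether the same change gives a step of this kind on the core of compound 1.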